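Replacing the chloropropylamino arm of compound 1

The source may report more compounds than this note shows. Statements on the series, on what has been measured and on what is new or still open speak of the compounds shown alone.

In a functional assay on MCF7 cells (Homo sapiens) for antiproliferative activity, with a stated time of 48 h (a lower number here means a stronger inhibitor, a higher number a weaker inhibitor), compound 1 `O=C(NCCCCl)Nc1ccc(I)cc1` gives only a limit, > 100000 nM. Compound 3 `CCCCC(O)c1cccc(NC(=O)NCCCCl)c1` also reaches only a limit, > 100000 nM. Compound 2 `CC(C)(C)c1ccc(NC(=O)NCCCCl)cc1`, by contrast, gives a number, 49000 nM. Going by the values given here, the one step between measured compounds that differ in a single place is an at least 2.0-fold lower number from compound 1 to compound 2 (0.30 log units; that floor lies within the scatter); it starts from the limit of > 100000 nM in this assay, at which 2 of the 3 values shown sit, so its true size is not known, and it concerns an aromatic carbon rather than the carbonyl carbon that is changed next.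

Compound 4 `O=C(CCl)Nc1ccc(I)cc1` differs from compound 1 in one place: chloromethyl in place of (3-chloropropyl)amino on a carbonyl carbon. Among the compounds with values here, no measured step touches this part of the shared core, so the measured results give no direction for this change. Within the data shown here, compound 1 stands at the assay limit, and nothing among the measured compounds points to a large gain or loss from swapping the arm on the carbonyl carbon. With the expectation left open in both directions, the estimate for compound 4 in this assay is 60000 nM, with a range from 8000 nM to 300000 nM, and a real chance that only a limit is reported again. For compound 4 this means an expected step of an at least 1.6-fold lower number from compound 1 to compound 4 (0.22 log units; that floor lies within the scatter).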

Compound 4, half-maximal inhibitory concentration: 6200 nM
Beside the measured number, compound 4's estimate is 9.7-fold (0.99 log units) above it, outside the stated range (below it).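

In this assay, chloromethyl in place of (3-chloropropyl)amino on a carbonyl carbon gives an at least 16-fold lower number from compound 1 to compound 4 (1.20 log units; beyond the scatter), so the arm on this carbonyl carbon can shift the read-out beyond the scatter. The earlier change on an aromatic carbon, an at least 2.0-fold lower number from compound 1 to compound 2 (0.30 log units; that floor lies within the scatter), could not show this, since its floor lies within the scatter. The true size of the new step is still unknown, since it starts from the value of compound 1, which is only a limit: the limit of > 100000 nM in this assay, at which 2 of the 4 values shown sit.

The change from compound 1 to compound 4 shortens the arm and also removes the hydrogen-bond donor of (3-chloropropyl)amino, and this single step cannot tell which of the two matters, or whether both do. The compounds shown also leave open whether a longer chain without that nitrogen, such as 3-chloropropyl on the same carbonyl carbon, would keep the gain, and what an amine or a simple methyl in place of the chlorine in chloromethyl would do.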